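Chain length at the aryl ether: compound 2 to compound 4

A few compounds are considered here, and "the series" means these few. Any claim that something is new, unique, unknown or untested is made for them only; others in the source may bear on it.

Measured so far in an assay (Cricetulus griseus) for inhibition of aldehyde dehydrogenase, mitochondrial (Homo sapiens); a higher number here means a weaker inhibitor, a lower number a stronger inhibitor:
compound 1, `CCCCCCOc1ccc2c(=O)c(-c3ccc(O)cc3)coc2c1`, 1500 nM
compound 2, `CCOC(=O)COc1ccc2c(=O)c(-c3ccc(O)cc3)coc2c1`, 130 nM
compound 3, `C=CCOc1ccc2c(=O)c(-c3ccc(O)cc3)coc2c1`, 180 nM

Compound 2 gives the lowest number of the three; compound 3 sits within the scatter of it, a 1.4-fold higher number from compound 2 to compound 3 (0.14 log units; within the scatter), while compound 1 sits far higher, a 12-fold lower number from compound 1 to compound 2 (1.06 log units; beyond the scatter). The unmeasured compound 4, `O=C(O)CCCCCCOc1ccc2c(=O)c(-c3ccc(O)cc3)coc2c1`, differs from compound 2 by 5-carboxypentyl in place of ethoxycarbonyl on a saturated chain carbon bound to an oxygen on an aromatic ring.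

Among the measured compounds shown here, the steps that bear on this are those leaving compound 1: a 12-fold lower number from compound 1 to compound 2 (1.06 log units; beyond the scatter) and an 8.3-fold lower number from compound 1 to compound 3 (0.92 log units; beyond the scatter). Both replace a long pentyl on that carbon with a short group and both lower the number well beyond the scatter. Compound 4 carries a six-carbon chain on the same carbon, closer in length to compound 1 than to compound 2 or compound 3, with the carboxylic acid at its far end. For the measured compounds named here, no measured pair shows what the acid alone does. The expectation is therefore a step back toward compound 1, estimated as a 5.4-fold higher number from compound 2 to compound 4 (0.73 log units; beyond the scatter) in this assay. Compound 4 is estimated at 700 nM, with a range from 200 nM to 2500 nM.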

Compound 4, half-maximal inhibitory concentration: 50 nM
Beside the measured number, compound 4's estimate is 14-fold (1.15 log units) above it; the whole stated range lies above it.
By their numbers in this assay, from the lowest: compound 4; then compounds 2 and 3 (each within the scatter of the next); then compound 1.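

In this assay, a long chain at this position does not by itself raise the number: with a carboxy group at its end, the chain gives the lowest number of the four compounds, with a 2.6-fold lower number from compound 2 to compound 4 (0.41 log units; beyond the scatter) and a 3.6-fold lower number from compound 3 to compound 4 (0.56 log units; beyond the scatter). Among the compounds shown here, the terminal group matters more than the earlier compounds could show, as carboxy in place of hydrogen at the end of the chain of compound 1 gives a 30-fold lower number from compound 1 to compound 4 (1.48 log units; beyond the scatter), so compound 1 alone fits the earlier link between a long chain and a high number. Nothing available explains this change in the number.

The compounds shown leave open how the number moves with a shorter or longer chain ending in a carboxylic acid. Also open, as far as these compounds go, is whether an ethyl ester or a primary amide at the same chain end would keep the number of the acid.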